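Methoxyphenyl position swap in a sulfonamide benzamide series

A few compounds are considered here, and "the series" means these few. Any claim that something is new, unique, unknown or untested is made for them only; others in the source may bear on it.

Three compounds of the series carry numbers in a functional assay on A549 cells (Homo sapiens) for inhibition, read by MTT assay, with a stated time of 48 h; on this read-out higher numbers stand for weaker inhibition and lower numbers for stronger inhibition. Compound 1 `COc1ccc(-n2cc(NC(=O)c3cccc(NS(=O)(=O)c4ccccc4)c3)cn2)cc1` gives 76800 nM. Compound 2 `COc1cccc(-n2cc(NC(=O)c3cccc(NS(=O)(=O)c4ccccc4)c3)cn2)c1` gives 81100 nM in this assay. Compound 3 `COc1ccc(-n2cc(NC(=O)c3ccc(NS(=O)(=O)c4ccccc4)cc3)cn2)cc1` gives 85800 nM in this assay. All three numbers lie within the usual scatter of one another, so no order among them is drawn.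

Among the compounds with values here, the one measured single change is from compound 1 to compound 2: 3-methoxyphenyl in place of 4-methoxyphenyl on an aromatic nitrogen. It produced a 1.1-fold higher number from compound 1 to compound 2 (0.02 log units; within the scatter). The difference between the core of compound 1 and the core of compound 3 is not broken down here; their values in this assay show only that they fall within the scatter of each other.

Compound 4 `COc1cccc(-n2cc(NC(=O)c3ccc(NS(=O)(=O)c4ccccc4)cc3)cn2)c1` has not yet been measured. Within the data shown here, it differs from compound 3 by 3-methoxyphenyl in place of 4-methoxyphenyl on an aromatic nitrogen, which is the same change, at the same place, as the one from compound 1 to compound 2. Because a 1.1-fold higher number from compound 1 to compound 2 (0.02 log units; within the scatter) fell within the scatter, the step of a 1.0-fold higher number from compound 3 to compound 4 (0.02 log units; within the scatter) is expected to be of like size, essentially flat. This rests on a single prior instance of the change, and on all three measured numbers in this assay standing close together.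

Compound 4 is estimated at 90000 nM in this assay, with the expected range running from 55000 nM to 150000 nM.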

Compound 4, half-maximal inhibitory concentration: > 100000 nM
Compound 4 ended at the assay's limit; the forecaster's own chance of this, stated with the estimate: 15%; at least 1.1-fold (0.04 log units) between middle value and limit.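

In this assay compound 4 gives > 100000 nM, which is a limit of the assay and not a number. Going by these compounds, on the core of compound 3, the change from 4-methoxyphenyl to 3-methoxyphenyl on the aromatic nitrogen gives an at least 1.1-fold higher number from compound 3 to compound 4 (0.06 log units; that floor lies within the scatter); only this floor can be read, so the full size of the step remains unknown. The change has now been seen on two cores, but this does not establish that it carries from one core to the other with the same size, nor that its size depends on the core: the same change on two cores in this assay, a 1.1-fold higher number (0.02 log units; within the scatter) from compound 1 to compound 2 and an at least 1.1-fold higher number (0.06 log units; that floor lies within the scatter) from compound 3 to compound 4; the limit leaves it open whether they differ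

All four compounds shown keep a methoxyphenyl group on the aromatic nitrogen and an unsubstituted phenyl on the sulfonamide, so it remains open how an amine, a carboxylic acid or a longer chain in place of the methoxy group would read in this assay. Also open, on these data alone, is whether such a group would separate a compound from compound 1 at 76800 nM by more than the scatter. As far as these compounds go, it is likewise open whether the two methoxyphenyl groups could be compared on a core where neither value meets the limit.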